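Azetidinone Triazoles Against KB Cell Growth

A few compounds are considered here, and "the series" means these few. Any claim that something is new, unique, unknown or untested is made for them only; others in the source may bear on it.

Measured compounds in a functional assay on KB cells (Homo sapiens) for inhibition, tested at 10 uM; a lower number here means less inhibition of growth, a higher number more inhibition of growth at the concentration tested:
compound 1 `COC(=O)c1nnn([C@@H]2C(=O)N(C3CCCCC3)[C@@H]2/C=C/c2ccccc2)c1C(=O)OC`: -7.7%
compound 2 `O=C1[C@@H](n2cc(-c3ccccc3)nn2)[C@@H](/C=C/c2ccccc2)N1C1CCCCC1`: 76.8%
compound 3 `COC(=O)c1nnn([C@@H]2C(=O)N(c3ccc(Cl)cc3)[C@@H]2/C=C/c2ccccc2)c1C(=O)OC`: 19.5%

In this assay compound 2 stands highest, and its steps to compound 3 and compound 1 lie beyond the scatter. How the core of compound 2 differs from that of compound 1 is not broken down here. Between compound 1 and compound 3 the change is 4-chlorophenyl in place of cyclohexyl on an amide-type nitrogen in a ring, and it gave a number 27.2 percentage points higher from compound 1 to compound 3 (beyond the scatter).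

Compound 4 `O=C1[C@@H](n2cc(-c3ccccc3)nn2)[C@@H](/C=C/c2ccccc2)N1c1ccc(Cl)cc1` awaits measurement. It differs from compound 2 by 4-chlorophenyl in place of cyclohexyl on an amide-type nitrogen in a ring, the same change at the same place. Because the earlier step of a number 27.2 percentage points higher from compound 1 to compound 3 (beyond the scatter) was modest and compound 2 already sits high, a smaller rise is expected from compound 2 to compound 4, about a number 8.2 percentage points higher from compound 2 to compound 4 (within the scatter). Compound 4 is therefore estimated at 85%, within 65% to 100%.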

Compound 4, percent growth inhibition at one concentration: 16.8%
Estimate against measurement, compound 4: 68.2 percentage points above; the measured number lies below the stated range.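

In this assay, replacing cyclohexyl with 4-chlorophenyl on the amide-type nitrogen gave a number 60 percentage points lower from compound 2 to compound 4 (beyond the scatter). The same change therefore did not carry from one core to the other in this series, and its direction reversed: the same change on two cores in this assay, a number 27.2 percentage points higher (beyond the scatter) from compound 1 to compound 3 and a number 60 percentage points lower (beyond the scatter) from compound 2 to compound 4, 87.2 percentage points apart, beyond the scatter of two such steps

Within the data shown here, with only one pair on each of two cores, this shows that the outcome on one core did not predict the outcome on the other, but not which part of the cores accounts for the difference or how the change would behave on a third core. The compounds shown leave open whether the reversal would persist with a benzyl or an unsubstituted phenyl group on that nitrogen. They also leave open what a carboxylic acid in place of the methyl esters of compound 1 would do.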